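Cytotoxicity notes: step from compound 3 to compound 4

The source may report more compounds than this note shows. Statements on the series, on what has been measured and on what is new or still open speak of the compounds shown alone.

In a functional assay on MT4 cells (Homo sapiens) for cytotoxicity (a higher number here means that more compound is tolerated, a lower number that less compound is tolerated), compound 3 `Cc1cn([C@@H]2O[C@H](CO[Si](C)(C)C(C)(C)C)[C@@]3(OS(=O)(=O)C=C3N)[C@H]2O[Si](C)(C)C(C)(C)C)c(=O)nc1N` gives 31000 nM, the highest of the two numbers in hand. Compound 2 `CC(C)(C)[Si](C)(C)OC[C@H]1O[C@@H](n2ccc(=O)[nH]c2=O)[C@H](O[Si](C)(C)C(C)(C)C)C12OS(=O)(=O)C=C2N` gives 15000 nM, a lower number, beyond the usual scatter. Compound 1 `CC(=O)O[C@H]1[C@H](n2cc(C)c(=O)[nH]c2=O)O[C@H](COC(=O)c2ccccc2)[C@@]12OS(=O)(=O)C=C2N` sits at a limit, not a number, with > 200000 nM (the limit of > 200000 nM in this assay, at which 1 of the 3 values shown sits). Compound 4 `C=CCn1c(=O)c(C)cn([C@@H]2O[C@H](CO[Si](C)(C)C(C)(C)C)[C@@]3(OS(=O)(=O)C=C3N)[C@H]2O[Si](C)(C)C(C)(C)C)c1=O` carries a group of 12 heavy atoms (8 carbon, 2 nitrogen, 2 oxygen; one six-membered aromatic ring with 2 hetero atoms) in place of a group of 9 heavy atoms (5 carbon, 3 nitrogen, 1 oxygen; one six-membered aromatic ring with 2 hetero atoms), on a saturated ring carbon, a group of 12 heavy atoms (8 carbon, 2 nitrogen, 2 oxygen; one six-membered aromatic ring with 2 hetero atoms) in place of a group of 9 heavy atoms (5 carbon, 3 nitrogen, 1 oxygen; one six-membered aromatic ring with 2 hetero atoms), on a saturated ring carbon. Going by the values given here, no measured pair mirrors this change, so no step size can be drawn from the data. A step of a 1.6-fold lower number from compound 3 to compound 4 (0.19 log units; within the scatter) is expected, small and not clearly beyond the scatter. Compound 4 is therefore estimated at 20000 nM, between 7000 nM and 70000 nM.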

Compound 4, half-maximal cytotoxic concentration: > 360000 nM
Compound 4: a limit, no number (the forecaster's own chance of this, stated with the estimate: 10%); at least 18-fold (1.25 log units) between middle value and limit.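

Replacing the group of 9 heavy atoms with the group of 12 heavy atoms, on a saturated ring carbon next to the ring oxygen, gives an at least 11-fold higher number from compound 3 to compound 4 (1.06 log units; beyond the scatter) in this assay. This shows that the group at this position can shift the tolerated concentration strongly while the two silyl ethers stay unchanged. The value of compound 4 is a limit, not a number: the limit of > 360000 nM in this assay, at which 1 of the 4 values shown sits.

The compounds shown leave open whether the step belongs to the allyl group or to the carbonyl that replaces the amine. Also open, going by these compounds, is how a propyl chain or a benzyl group in place of the allyl group would read.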